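Triazene series: butyl in place of phenyl at the amine carbon

The compounds below may be only part of what the source reports. "The series", "measured", "known", "first", "only" and "open" are said of these compounds alone.

Measured in a functional assay on L1210 cells (Mus musculus) for antiproliferative activity; on this read-out lower numbers stand for lower potency and higher numbers for higher potency (the scale is a negative logarithm):
compound 1 `CCCCN(C)/N=N/c1ccc([N+](=O)[O-])cc1C(N)=O`: 3.08
compound 2 `CN(C)/N=N/c1ccc(CCCC(=O)NN)cc1`: 3.6
compound 3 `CN(Cc1ccccc1)/N=N/c1nc[nH]c1C(N)=O`: 3.43

Compound 3 stands second highest of the three numbers. Its nearest neighbour is compound 2, whose number is higher by an amount within the scatter, so no order between compound 2 and compound 3 is claimed. Compound 1 lies furthest away, its number below compound 3 by an amount beyond the scatter. Among the measured compounds shown here, no pair of measured compounds differs in one place only, so no size of effect for a single change has been observed in this assay.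

Compound 4 `CCCCCN(C)/N=N/c1nc[nH]c1C(N)=O` differs from compound 3 by butyl in place of phenyl on a saturated chain carbon bound to an amine nitrogen. For the measured compounds named here, nothing among the measured compounds connects such a change to the read-out. The step from compound 3 to compound 4 is expected to be small, in either direction, and not beyond the scatter of this assay. On that basis compound 4 is expected at 3.4, with a range from 2.9 to 3.9. The expected step is a number 0.03 log units lower from compound 3 to compound 4 (within the scatter).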

Compound 4, logarithm of the reciprocal of the active concentration, log(1/C): 3.58
Compound 4: middle estimate off by 0.18 log units, on the low side; measured number inside the range.
By their numbers in this assay, from the lowest: compound 1; then compounds 3, 4 and 2 (each within the scatter of the next).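

Triazene series, notes on the butyl for phenyl change. Among the compounds shown here, this is the first step that differs in one place only. In this assay, butyl in place of phenyl on a saturated chain carbon bound to an amine nitrogen gives a number 0.15 log units higher from compound 3 to compound 4 (within the scatter), so at this place the aromatic ring of compound 3 can give way to the open chain of compound 4 without a difference that can be read. No measurement at hand bears on the reason for this result.

Still open, going by these compounds, is whether any group at this place moves the read-out beyond the scatter, for instance a longer chain, an amine or a carboxylic acid on the same chain carbon. Also open, on these data alone, is whether the same change behaves alike on the core of compound 1 or compound 2.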